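The source may report more compounds than this note shows. Statements on the series, on what has been measured and on what is new or still open speak of the compounds shown alone.

Compound 1: `Cc1c(O)c(=O)ccn1CC(=O)N/N=C1\C(=O)N(CC(=O)Nc2ccc(Cl)cc2)c2ccccc21` — 31400 nM
Compound 2: `Cc1c(O)c(=O)ccn1CC(=O)N/N=C1\C(=O)N(CC(=O)Nc2ccccc2Cl)c2ccccc21` — 46400 nM

Both compounds share the same core and differ only in where the chlorine sits on the phenyl ring that hangs from the amide-type nitrogen. In a functional assay on MCF7 cells (Homo sapiens) for cytotoxicity, read by MTT assay, with a stated time of 48 h (a higher number here means that more compound is needed for the effect, a lower number that less compound is needed), compound 1 gives 31400 nM, and compound 2 gives 46400 nM. For the measured compounds named here, the single measured step, a 1.5-fold higher number from compound 1 to compound 2 (0.17 log units; within the scatter), is within the scatter, so the two compounds cannot be told apart on these numbers; compound 2 simply has the nearest and only companion in compound 1.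

Compound 3, `Cc1c(O)c(=O)ccn1CC(=O)N/N=C1\C(=O)N(CC(=O)Nc2cc(Cl)cc(Cl)c2)c2ccccc21`, carries the change (3,5-dichlorophenyl in place of 2-chlorophenyl on an amide-type nitrogen). Going by the values given here, the only step that bears on it is the move of the chlorine from one phenyl position to another, a 1.5-fold higher number from compound 1 to compound 2 (0.17 log units; within the scatter), which did not move the number beyond the scatter. Adding a second chlorine goes a little beyond what has been measured, but nothing in the data points in a direction. The expectation for compound 3 in this assay is therefore a step of about a 1.2-fold lower number from compound 2 to compound 3 (0.06 log units; within the scatter), that is, no change beyond the scatter. Compound 3 is estimated at 40000 nM, with a range from 15000 nM to 110000 nM.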

Compound 3, half-maximal effective concentration: 35100 nM
Estimate against measurement, compound 3: 1.1-fold (0.06 log units) above; low and high end bracket the measured number.
By their numbers in this assay, from the lowest: compounds 1, 3 and 2 (each within the scatter of the next).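

In this assay, the new compound tests something the first pair could not: the phenyl ring on the amide-type nitrogen now carries two chlorines, not one, as 3,5-dichlorophenyl. Yet a 1.3-fold lower number from compound 2 to compound 3 (0.12 log units; within the scatter) and a 1.1-fold higher number from compound 1 to compound 3 (0.05 log units; within the scatter) both lie within the scatter, so compound 3 cannot be told apart from either compound with a single chlorine. Across these three compounds, then, neither the placement of chlorine on this ring nor a second chlorine gives a measurable difference, no compound goes against that reading, and no other measurement is available to account for it.

From the compounds shown here alone, all three compounds carry only chlorine on this phenyl ring, so it remains open whether a group of another kind there, such as an amine or a carboxylic acid, or a longer chain in place of the ring, would give a step beyond the scatter. Going by these compounds, it also remains open whether a change elsewhere on the shared core, away from this amide-type nitrogen, would separate compounds that these chlorine changes leave together.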